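One side-chain change in a flat set of compounds

The compounds below may be only part of what the source reports. "The series", "measured", "known", "first", "only" and "open" are said of these compounds alone.

- compound 1 `COc1ccc2cc(-c3ccccc3)c(O)nc2c1` gives 10000 nM
- compound 2 `COc1ccc(-c2cc3cccc(OC)c3nc2O)cc1` gives 10000 nM
- compound 3 `CCOC(=O)Cn1c(=O)c(-c2ccc(OC)cc2)cc2c(OC)cc(OC)cc21` gives 10000 nM

These numbers come from a functional assay on PC-3 cells (Homo sapiens) for cytotoxicity, read by colorimetric assay and MTT assay; on this read-out lower numbers stand for stronger inhibition and higher numbers for weaker inhibition. In this assay compound 3 stands level with compound 1 and compound 2, and the gaps between them show no change at all. The three compounds carry different decorations, yet their readings match.

The next compound to be tested is compound 4 `COc1ccc(-c2cc3c(OC)cc(OC)cc3n(CCCC#N)c2=O)cc1`. It is made from compound 3 by a single edit: 2-cyanoethyl in place of ethoxycarbonyl on a saturated chain carbon bound to an aromatic nitrogen. Put simply, 2-cyanoethyl takes the place of ethoxycarbonyl on a saturated chain carbon bound to an aromatic nitrogen, and the rest of the molecule stays the same.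

Among the measured compounds shown here, no pair of measured compounds differs in one place only, so the data hold no direct guide to the size of such a step. The best available anchor is compound 3 at 10000 nM, and compound 1 and compound 2 give the same reading. On that basis, no shift beyond the usual scatter is expected in this assay, in either direction. The expected change is no change at the digits printed from compound 3 to compound 4 (within the scatter).

For compound 4 the estimate is 10000 nM, with an expected range from 3000 nM to 15000 nM.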

Compound 4, half-maximal inhibitory concentration: 10000 nM
The estimate for compound 4 equals the measured number at the digits printed, within the range that was stated.
By their numbers in this assay, from the lowest: compounds 1, 2, 3 and 4 (each within the scatter of the next).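

In this assay the reading shows no change at the digits printed from compound 3 to compound 4 (within the scatter) when 2-cyanoethyl takes the place of ethoxycarbonyl on a saturated chain carbon bound to an aromatic nitrogen. Among the compounds shown here, this is the first step in the set that changes one place only, so it gives a direct look at this position that the earlier side-by-side readings could not give: a chain ending in a nitrile and one ending in ethoxycarbonyl read the same here, even though the two groups share little beyond their carbon count. No measurement shown here bears on why the reading holds still, so this single step records the outcome and offers no explanation.

All four compounds share one reading, so the set does not yet show any change that moves the number in either direction, at this position or elsewhere on the shared core. From the compounds shown here alone, whether a carboxylic acid, an amine or a much longer chain in this same place would shift the reading remains open.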